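Swapping the aryl group on an aromatic nitrogen

The source may hold more compounds than are shown below. What is called first, only, known or untested is meant among the compounds shown, and "the series" means these compounds.

Compound 1 `Cc1ccccc1-n1nncc1CN1C(=O)C2(C(C#N)=C(N)Oc3c(N)cc4nc5ccccc5nc4c32)c2ccccc21` in a functional assay on HCT-116 cells (Homo sapiens) for antiproliferative activity, read by MTT assay, with a stated time of 48 h (on this read-out lower numbers stand for stronger inhibition and higher numbers for weaker inhibition), reaches only the limit > 50000 nM. Compound 2 `N#CC1=C(N)Oc2c(N)cc3nc4ccccc4nc3c2C12C(=O)N(Cc1cnnn1-c1cccc(Br)c1)c1ccccc12` gives 26100 nM in this assay. Compound 3 `CCc1cccc(CC)c1-n1nncc1CN1C(=O)C2(C(C#N)=C(N)Oc3c(N)cc4nc5ccccc5nc4c32)c2ccccc21` gives 37600 nM in this assay.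

All three share one core and differ only in the aryl group carried on an aromatic nitrogen. Compound 3 holds the higher of the two actual numbers, but the gap to the other number is small: a 1.4-fold higher number from compound 2 to compound 3 (0.16 log units; within the scatter). For the measured compounds named here, the first compound offers no number at all, only (the limit of > 50000 nM in this assay, at which 1 of the 3 values shown sits), so the two steps starting there are floors: an at least 1.9-fold lower number from compound 1 to compound 2 (0.28 log units; that floor lies within the scatter) and an at least 1.3-fold lower number from compound 1 to compound 3 (0.12 log units; that floor lies within the scatter). None of these steps reaches beyond the usual scatter, so the aryl swaps seen so far have shifted the read-out little.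

Compound 4 `Cc1ccc(-n2nncc2CN2C(=O)C3(C(C#N)=C(N)Oc4c(N)cc5nc6ccccc6nc5c43)c3ccccc32)cc1Cl` is the next variation of the same kind: 3-chloro-4-methylphenyl in place of 2,6-diethylphenyl on an aromatic nitrogen. Since every aryl swap measured so far stayed within the scatter, no step beyond the scatter is expected in this assay, in either direction. Compound 4 is therefore estimated at 30000 nM, with a range from 12000 nM to 80000 nM. The expected step is a 1.3-fold lower number from compound 3 to compound 4 (0.10 log units; within the scatter), which is small, and a limit rather than a number remains a real possibility.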

Compound 4, half-maximal inhibitory concentration: > 50000 nM
Compound 4: only a limit was reported (the forecaster's own chance of this, stated with the estimate: 30%); at least 1.6-fold (0.22 log units) between middle value and limit.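

In this assay compound 4 gives a limit, not a number: > 50000 nM. The steps to it are therefore only floors, an at least 1.3-fold higher number from compound 3 to compound 4 (0.12 log units; that floor lies within the scatter) and an at least 1.9-fold higher number from compound 2 to compound 4 (0.28 log units; that floor lies within the scatter), and the steps with a limit at both ends cannot be read. The new point is that 3-chloro-4-methylphenyl, a smaller group by heavy atoms than 2,6-diethylphenyl and the first here to carry both chlorine and methyl, still produces no step shown to lie beyond the scatter, and the limit has now been met with a second aryl group on this aromatic nitrogen, which makes it a recurring outcome for this series rather than a single case: the limit of > 50000 nM in this assay, at which 2 of the 4 values shown sit.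

On these data alone, how far compound 1 and compound 4 truly lie from compound 2 and compound 3 remains unknown, so the floors cannot rank these aryl groups. As far as these compounds go, it also remains open whether a phenyl ring bearing an amine or a carboxylic acid, or a longer chain in place of the aryl group, would move the read-out beyond the scatter.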